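The source may hold more compounds than are shown below. What is called first, only, known or untested is meant among the compounds shown, and "the series" means these compounds.

Measured in a functional assay on the whole organism with Mus musculus as the target, in the maximal electroshock model; on this read-out higher numbers stand for an effect only at larger amounts of compound and lower numbers for an effect already at smaller amounts:
Compound 1 `O=COC1CCN(c2ccc(-c3ccc(Cl)cc3Cl)nn2)CC1`: 24 mg/kg
Compound 2 `CNC(=O)OC1CCN(c2ccc(-c3ccccc3Cl)nn2)CC1`: 10 mg/kg

Of these two, compound 2 has the lower number, so it shows its effect at the smaller dose, and its gap to compound 1 lies beyond the usual scatter. The next compound to be tested is compound 3 `CNC(=O)OC1CCN(c2ccc(-c3ccc(Cl)cc3Cl)nn2)CC1`. It comes from compound 2 through a single change: chloro in place of hydrogen on an aromatic carbon. With chloro in place of hydrogen on an aromatic carbon, 2-chlorophenyl becomes 2,4-dichlorophenyl. Among the compounds with values here, no pair of measured compounds shows this change on its own, so the expectation in this assay simply starts from compound 2 at 10 mg/kg. No step beyond the scatter is expected, in either direction. The estimated change is a 1.3-fold higher number from compound 2 to compound 3 (0.11 log units; within the scatter), which would stay within the scatter. For compound 3 the expected value is 13 mg/kg, with an estimated range of 5 mg/kg to 32 mg/kg.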

Compound 3, dose for half-maximal effect: 5.5 mg/kg
The estimate for compound 3 lay 2.4-fold (0.37 log units) above the measured number; the measured number falls inside the stated range.
By their numbers in this assay, from the lowest: compounds 3 and 2 (each within the scatter of the next); then compound 1.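

In this assay, adding chloro para to a large group, which turns 2-chlorophenyl into 2,4-dichlorophenyl, gives a 1.8-fold lower number from compound 2 to compound 3 (0.26 log units; within the scatter), so this position accepts a chloro group without a change that can be told from the scatter. Within the data shown here, compounds 1 and 2 differ in two places, but compound 3 allows the first comparison of a single change at the carbonyl carbon: with 2,4-dichlorophenyl kept in place, methylamino in place of hydrogen gives a 4.4-fold lower number from compound 1 to compound 3 (0.64 log units; beyond the scatter), a modest step beyond the scatter. Nothing measured here explains either step.

The compounds shown leave open whether fluoro or methoxy at the same aromatic carbon would behave like chloro. They also leave open whether ethylamino or dimethylamino on the carbonyl carbon would keep the step seen with methylamino.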